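The source may hold more compounds than are shown below. What is called first, only, known or untested is meant among the compounds shown, and "the series" means these compounds.

Within the data shown here, compound 2 `O=CNC[C@H]1CN(c2ccc(-n3cc(-c4ccccn4)cn3)c(F)c2)C(=O)O1` stands at the lower of the two numbers measured so far: in a physicochemical assay for lipophilicity, read by HPLC, measured as octanol-water partition (on this read-out lower numbers stand for lower lipophilicity and higher numbers for higher lipophilicity), compound 2 gives 1.19, while compound 1 `O=C1O[C@@H](CN2CCC(O)CC2)CN1c1ccc(-n2cc(-c3ccccn3)cn2)c(F)c1` gives 1.63. Among the measured compounds shown here, the one measured step, a number 0.44 log units lower from compound 1 to compound 2 (beyond the scatter), shows how far a single change at the side group on the shared core has moved the read-out.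

Compound 3 `NC(=O)[C@H]1CN(c2ccc(-n3cc(-c4ccccn4)cn3)c(F)c2)C(=O)O1` differs from compound 2 in one place, (carbamoyl in place of (formylamino)methyl on a saturated ring carbon). The measured step from compound 1 to compound 2 concerns a different exchange, so it does not bear directly on this one; it only shows that a change of this kind at this part of the molecule can shift the number by a modest amount. Both the leaving group and the entering group carry one hydrogen-bond donor and one hydrogen-bond acceptor, and the entering group is one heavy atom smaller. The expectation is therefore a small downward step, a number 0.19 log units lower from compound 2 to compound 3 (within the scatter), though one that may fall within the scatter. Compound 3 is expected to give 1 in this assay, within a range from 0.6 to 1.4.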

Compound 3, partition coefficient: 1.59
Compound 3: middle estimate off by 0.59 log units, on the low side; the whole stated range lies below it.
By their numbers in this assay, from the lowest: compound 2; then compounds 3 and 1 (each within the scatter of the next).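

In this assay, putting carbamoyl in place of (formylamino)methyl on this saturated ring carbon gives a number 0.40 log units higher from compound 2 to compound 3 (beyond the scatter), even though both groups carry the same number of hydrogen-bond donors and acceptors and neither has a net charge, so those counts alone do not fix the number at this position. Carbamoyl and the far larger (4-hydroxypiperidin-1-yl)methyl give values that cannot be told apart, with a number 0.04 log units lower from compound 1 to compound 3 (within the scatter), which means group size does not order these three compounds: compound 2, with a group larger than carbamoyl and smaller than (4-hydroxypiperidin-1-yl)methyl, is the one that stands apart from the other two. Nothing available here explains why the number rises with this exchange.

Carbamoyl differs from (formylamino)methyl both in the length of its link to the ring and in the direction of its amide, so these compounds leave open which of the two differences matters. A carbamoylmethyl group would keep the link and change only the direction of the amide, while a carboxylic acid or a simple aminomethyl group at the same carbon would show how far the number depends on having an amide there at all.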